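Fluoro in place of (bromomethyl)carbonyl: an expected longer half-life

The source may report more compounds than this note shows. Statements on the series, on what has been measured and on what is new or still open speak of the compounds shown alone.

The measured compounds in an ADME assay for pharmacokinetics, read by LC-MS, in phosphate buffer, with a stated time of 72 h, at pH 7.4, tested at 250 uM; on this read-out higher numbers stand for a longer-lived compound and lower numbers for a shorter-lived compound:
compound 1, `C=CC(=O)Oc1cc(C(F)(F)F)cc(C(F)(F)F)c1`, gives < 0.017 h, a limit of the assay.
compound 2, `N#Cc1cc(C(F)(F)F)cc(C(F)(F)F)c1`, gives > 50 h, a limit of the assay.
compound 3, `O=C(CBr)c1cc(C(F)(F)F)cc(C(F)(F)F)c1`, gives < 0.017 h, a limit of the assay.

Compound 3 thus stands at the short-lived end of what the assay can report, and only a limit is known for it. Two of the three values sit at the limit of < 0.017 h in this assay, at which 2 of the 3 values shown sit, and one sits at the limit of > 50 h in this assay, at which 1 of the 3 values shown sits. The steps between the measured compounds are correspondingly large where they can be read: an at least 2900-fold higher number from compound 1 to compound 2 (3.46 log units; beyond the scatter), and an at least 2900-fold lower number from compound 2 to compound 3 (3.46 log units; beyond the scatter). The step that the two limits leave unreadable from compound 1 to compound 3, since both ends are limits.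

Compound 4 is `Fc1cc(C(F)(F)F)cc(C(F)(F)F)c1`. Relative to compound 3 the change is fluoro in place of (bromomethyl)carbonyl on an aromatic carbon. Going by the values given here, the step that bears most directly on it is the one from compound 2 to compound 3, in which the (bromomethyl)carbonyl group was the entering group and the half-life fell by a large amount; the present change removes that same group. Compound 4 is therefore expected to show a large rise, an at least 5800-fold higher number from compound 3 to compound 4 (3.76 log units; beyond the scatter), in this assay, and the estimate for compound 4 is 100 h, within 20 h to 500 h.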

Compound 4, half-life: > 50 h
Compound 4 ended at the assay's limit; the forecaster's own chance of this, stated with the estimate: 80%; the middle value does not contradict the limit.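

Compound 4 shows that the long-lived end of the scale at this aromatic carbon, meta to two trifluoromethyl groups, is not reached by the nitrile of compound 2 alone, since replacing (bromomethyl)carbonyl with fluoro gives an at least 2900-fold higher number from compound 3 to compound 4 (3.46 log units; beyond the scatter), and replacing (vinylcarbonyl)oxy with fluoro gives an at least 2900-fold higher number from compound 1 to compound 4 (3.46 log units; beyond the scatter). In this assay compound 4 gives > 50 h, which is a limit of the assay. Among the compounds shown, the groups at this one place now divide evenly, with (vinylcarbonyl)oxy and (bromomethyl)carbonyl at one end and cyano and fluoro at the other, and the step between compound 2 and compound 4 cannot be read, as the upper end now holds as many compounds as the lower: the limit of > 50 h in this assay, at which 2 of the 4 values shown sit.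

As far as these compounds go, how far compound 2 and compound 4 lie beyond that limit, and whether they differ from each other at all, remains open. Also open, from the compounds shown here alone, is where an amine, a carboxylic acid or a longer alkyl chain at this aromatic carbon would fall, as every value shown so far sits at one limit or the other and none lies within the measurable range.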